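Cytotoxicity notes: sulfamoyl replacing (isopropylsulfonyl)amino on the core

The compounds below may be only part of what the source reports. "The series", "measured", "known", "first", "only" and "open" are said of these compounds alone.

Measured compounds:
compound 1 `CCS(=O)(=O)Nc1ccc2c(c1)S(=O)(=O)N=C(c1c(O)c(-c3cccs3)nn(CCC(C)C)c1=O)N2` — > 33000 nM (a limit)
compound 2 `CC(C)CCn1nc(-c2cccs2)c(O)c(C2=NS(=O)(=O)c3cc(NS(=O)(=O)C(C)C)ccc3N2)c1=O` — > 1000 nM (a limit)
compound 3 `CCCS(=O)(=O)Nc1ccc2c(c1)S(=O)(=O)N=C(c1c(O)c(-c3cccs3)nn(CCC(C)C)c1=O)N2` — > 1000 nM (a limit)

In an ADME assay on Huh-7 cells (Homo sapiens) for cytotoxicity, with a stated time of 72 h (a higher number here means that more compound is tolerated, a lower number that less compound is tolerated), compound 1 gives > 33000 nM, which is a limit of the assay and not a number. Compound 2 gives > 1000 nM, again only a limit. Compound 3 gives > 1000 nM, also a limit. Compound 2 therefore stands at the lower of the two limits shown, with no number of its own; all three values in the series are limits (the limit of > 1000 nM in this assay, at which 2 of the 3 values shown sit; (the limit of > 33000 nM in this assay, at which 1 of the 3 values shown sits)). The steps a step that the two limits leave unreadable from compound 1 to compound 2, a step that the two limits leave unreadable from compound 1 to compound 3 and a step that the two limits leave unreadable from compound 2 to compound 3 are accordingly unreadable in size, because the limit of > 1000 nM in this assay, at which 2 of the 3 values shown sit, and the limit of > 33000 nM in this assay, at which 1 of the 3 values shown sits, enclose them.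

Compound 4 `CC(C)CCn1nc(-c2cccs2)c(O)c(C2=NS(=O)(=O)c3cc(S(N)(=O)=O)ccc3N2)c1=O` differs from compound 2 as follows: sulfamoyl in place of (isopropylsulfonyl)amino on an aromatic carbon. Within the data shown here, none of the measured steps touches this group, so no step bears directly on the change; the three measured compounds merely show tolerance up to their limits. No step beyond the scatter is expected, and a limit remains the most likely read-out. Compound 4 is estimated at 30000 nM, range 5000 nM to 100000 nM. The expected step from compound 2 is a step that the limit leaves unreadable from compound 2 to compound 4.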

Compound 4, half-maximal cytotoxic concentration: > 33000 nM
Compound 4: only a limit was reported (the forecaster's own chance of this, stated with the estimate: 80%); middle value at least 1.1-fold (0.04 log units) away from the limit.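

In this assay compound 4 gives > 33000 nM, a limit of the assay and not a number. Among these compounds, no step between compound 4 and compound 1, compound 2 or compound 3 can be read. The compounds shown leave open whether sulfamoyl in place of the sulfonylamino groups shifts tolerance at all.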